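Swapping the amide nitrogen group: 4-chlorobenzyl to phenyl

A few compounds are considered here, and "the series" means these few. Any claim that something is new, unique, unknown or untested is made for them only; others in the source may bear on it.

Compound 1, `C=CC1=C(C(=O)NCc2ccccc2)C(c2ccc(OC)c(OC)c2)OC1`: > 100000 nM
Compound 2, `C=CC1=C(C(=O)NC2CCCCC2)C(c2ccc(OC)c(OC)c2)OC1`: > 100000 nM
Compound 3, `C=CC1=C(C(=O)NCc2ccc(Cl)cc2)C(c2ccc(OC)c(OC)c2)OC1`: > 100000 nM

Of the compounds shown here, three that share one core have been tested in a functional assay on A549 cells (Homo sapiens) for cytotoxicity, read by MTT assay, with a stated time of 24 h; on this read-out lower numbers stand for stronger inhibition and higher numbers for weaker inhibition. In this assay compound 1 gives > 100000 nM, which is a limit of the assay and not a number. Compound 2 gives > 100000 nM, also a limit. Compound 3 gives > 100000 nM, again a limit. Because all three values sit at the same limit (the limit of > 100000 nM in this assay, at which 3 of the 3 values shown sit), the steps between them cannot be read: a step that the two limits leave unreadable from compound 1 to compound 2, a step that the two limits leave unreadable from compound 1 to compound 3, and a step that the two limits leave unreadable from compound 2 to compound 3. Compound 3 therefore stands nowhere more precisely than at that limit, alongside the other two.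

Compound 4, `C=CC1=C(C(=O)Nc2ccccc2)C(c2ccc(OC)c(OC)c2)OC1`, has not yet been measured. Its difference from compound 3 is phenyl in place of 4-chlorobenzyl on an amide-type nitrogen. Among the compounds with values here, none of the measured steps has a readable size, so none points in a direction; changing the group on the amide-type nitrogen from benzyl to cyclohexyl or to 4-chlorobenzyl left every value at the limit. On that basis compound 4 is expected to give 100000 nM, with a range from 50000 nM to 300000 nM. The expected step is thus a number no higher from compound 3 to compound 4 (the limit leaves the size open), none beyond the scatter, most likely reported again only as a limit.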

Compound 4, half-maximal inhibitory concentration: > 100000 nM
Compound 4: only a limit was reported; the forecaster's own chance of this, stated with the estimate: 85%; the middle value lies on the limit itself.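

In this assay compound 4 gives > 100000 nM, which is a limit of the assay and not a number. No step from compound 1, compound 2 or compound 3 to compound 4 can be read, because all four compounds sit at the same limit: the limit of > 100000 nM in this assay, at which 4 of the 4 values shown sit.

The compounds shown leave open whether any group on the amide-type nitrogen can give a measurable value in this assay.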